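Adding a phenyl at the ether carbon of compound 1

The compounds below may be only part of what the source reports. "The series", "measured", "known", "first", "only" and "open" are said of these compounds alone.

For the measured compounds named here, in an assay on membranes from brain for binding affinity to Fatty-acid amide hydrolase 1 (Mus musculus), read by fluorescence, with stated times of 1 h and 30 min (on this read-out lower numbers stand for stronger inhibition and higher numbers for weaker inhibition), compound 1 `O=C(NCc1ccc(OCc2ccccc2)cc1)n1cccn1` gives 800 nM, the highest of the two numbers so far. Going by the values given here, the only other compound, compound 2 `N#Cc1cnn(C(=O)NCc2ccc(OCc3ccccc3)cc2)c1`, gives 60 nM in this assay; that pair shows a 13-fold lower number from compound 1 to compound 2 (1.12 log units; beyond the scatter) for cyano in place of hydrogen on an aromatic carbon. Compound 3 `O=C(NCc1ccc(OC(c2ccccc2)c2ccccc2)cc1)n1cccn1` differs from compound 1 by phenyl in place of hydrogen on a saturated chain carbon bound to an aromatic carbon and an oxygen on an aromatic ring. Among the compounds with values here, the one measured step concerns the cyano on the shared core and does not bear on this position. A step of no change at the digits printed from compound 1 to compound 3 (within the scatter) in this assay is therefore expected for compound 3, none beyond the scatter. The estimate for compound 3 is 800 nM, between 200 nM and 3000 nM.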

Compound 3, half-maximal inhibitory concentration: > 100000 nM
Compound 3: a limit, no number; the forecaster's own chance of this, stated with the estimate: 5%; middle value at least 120-fold (2.09 log units) away from the limit.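

Phenyl in place of hydrogen on a saturated chain carbon bound to an aromatic carbon and an oxygen on an aromatic ring gives, in this assay, an at least 120-fold higher number from compound 1 to compound 3 (2.09 log units; beyond the scatter), the first evidence on this position. The earlier pair spoke only to cyano on the shared core; this carbon proves far less forgiving of added bulk in terms of the read-out alone. Compound 3 has a limit, not a number: the limit of > 100000 nM in this assay, at which 1 of the 3 values shown sits.

Going by these compounds, whether a methyl or hydroxyl at this carbon keeps inhibition remains open. So does whether cyano, as in compound 2, would bring a phenyl-bearing analogue back to a measurable number.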